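The compounds below may be only part of what the source reports. "The series", "measured", "known", "first", "only" and "open" are said of these compounds alone.

Compound 1 `COC(=O)CNc1cc(NS(=O)(=O)/C=C/c2c(OC)cc(OC)cc2OC)ccc1OC`: 350 nM
Compound 2 `COC(=O)C(Nc1cc(NS(=O)(=O)/C=C/c2c(OC)cc(OC)cc2OC)ccc1OC)c1ccc(Br)cc1`: 7500 nM

In a functional assay on DU-145 cells (Homo sapiens) for cytotoxicity, read by trypan blue exclusion, with a stated time of 96 h (on this read-out higher numbers stand for weaker inhibition and lower numbers for stronger inhibition), compound 2 gives 7500 nM, the higher of the two numbers measured. Compound 3 `COc1cc(OC)c(/C=C/S(=O)(=O)Nc2ccc(OC)c(NCC(=O)O)c2)c(OC)c1` differs from it as follows: carboxymethyl in place of (4-bromophenyl)(methoxycarbonyl)methyl on a nitrogen on an aromatic ring. Carboxymethyl thus replaces (4-bromophenyl)(methoxycarbonyl)methyl on a nitrogen on an aromatic ring. Among the measured compounds shown here, one measured step bears on this: a 21-fold higher number from compound 1 to compound 2 (1.33 log units; beyond the scatter), a large step that came with 4-bromophenyl in place of hydrogen. For the measured compounds named here, no measured step shows what carboxymethyl does alone. With the 4-bromophenyl gone, a large step to a lower number is expected in this assay. The expected step is a 38-fold lower number from compound 2 to compound 3 (1.57 log units; beyond the scatter). Compound 3 is estimated at 200 nM, with an expected range of 50 nM to 900 nM.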

Compound 3, half-maximal inhibitory concentration: 400 nM
Estimate against measurement, compound 3: 2.0-fold (0.30 log units) below, within the range that was stated.
By their numbers in this assay, from the lowest: compounds 1 and 3 (each within the scatter of the next); then compound 2.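

In this assay, a 19-fold lower number from compound 2 to compound 3 (1.27 log units; beyond the scatter), so carboxymethyl on a nitrogen on an aromatic ring returns to the level of compound 1. Hydrogen in place of methyl on an oxygen next to a carbonyl group gives a 1.1-fold higher number from compound 1 to compound 3 (0.06 log units; within the scatter), so at this position the methyl ester and carboxymethyl cannot be told apart in this read-out. No measurement given here explains either step.

On these data alone, whether an amide or a longer chain in place of carboxymethyl would keep this level stays open. So does what an ethyl group would do in place of the 4-bromophenyl.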